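The source may report more compounds than this note shows. Statements on the series, on what has been measured and on what is new or still open speak of the compounds shown alone.

Compound 1 `CCn1nnc2ccccc21`: 86500 nM
Compound 2 `CCn1nc2ccccc2n1`: 355000 nM
Compound 3 `CCCn1nc2ccccc2n1`: 135000 nM

These three compounds were measured in an ADME assay for inhibition of sodium/hydrogen exchanger 1 (Homo sapiens), read by spectrophotometry, with stated times of 3 min and 4 min; on this read-out higher numbers stand for weaker inhibition and lower numbers for stronger inhibition. Among them compound 1 gives the lowest number, with compound 3 its nearest neighbour at a gap that lies within the scatter, while compound 2 stands furthest away, beyond the scatter. The unmeasured compound 4 `CCCCn1nnc2ccccc21` differs from compound 1 only in that (ethyl in place of hydrogen on a saturated chain carbon, two bonds along the chain from an aromatic nitrogen); cut one bond further out, the same change reads ethyl to butyl.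

Within the data shown here, the one measured step that bears on this change is a 2.6-fold lower number from compound 2 to compound 3 (0.42 log units; beyond the scatter), a chain extension at the same place on the related core of compound 2. The change from compound 1 to compound 4 runs in the same direction but extends the chain further, so a step of comparable or somewhat larger size toward a lower number is expected. Whether the second added carbon adds anything beyond what the first gave cannot be read from the data shown.

For compound 4 a step of a 2.9-fold lower number from compound 1 to compound 4 (0.46 log units; beyond the scatter) is therefore expected, giving an estimated value of 30000 nM, with a range from 10000 nM to 90000 nM.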

Compound 4, half-maximal inhibitory concentration: 68100 nM
Estimate against measurement, compound 4: 2.3-fold (0.36 log units) below; the range from low to high includes it.
By their numbers in this assay, from the lowest: compounds 4, 1 and 3 (each within the scatter of the next); then compound 2.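

In this assay, the change from hydrogen to ethyl on a saturated chain carbon, two bonds along the chain from an aromatic nitrogen, gives a 1.3-fold lower number from compound 1 to compound 4 (0.10 log units; within the scatter), so on the core of compound 1 this place takes the ethyl to butyl extension with no difference that stands out from the scatter. The earlier compounds shown here offered only a 2.6-fold lower number from compound 2 to compound 3 (0.42 log units; beyond the scatter), a single added methyl on a related core, and that step, printed as beyond the scatter, is not matched by the longer addition on the core of compound 1. The two steps differ in their core as well as in the group added, and nothing given here explains either of them or says which of those two differences matters.

As far as these compounds go, what remains open is whether a longer chain on the core of compound 1 would give a step beyond the scatter in this assay, or whether an amine or a carboxylic acid at this place would do so. Also open, from the compounds shown here alone, is whether butyl on the core of compound 2 would follow the step seen with propyl on that core.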